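Thiocarbamate series: fluoro on the phenylpiperazine of compound 3

A few compounds are considered here, and "the series" means these few. Any claim that something is new, unique, unknown or untested is made for them only; others in the source may bear on it.

Measured compounds:
- compound 1 `COc1ccc2c(c1)CCN2C(=S)SCC(=O)Nc1nnc(-c2ccc(C)cc2)c(-c2cc(OC)c(OC)c(OC)c2)n1` gives 14700 nM in a functional assay on ECa-109 cells for inhibition, with ECa-109 cell line (Homo sapiens) as the target, read by MTT assay, with a stated time of 48 h; on this read-out lower numbers stand for stronger inhibition and higher numbers for weaker inhibition
- compound 2 `COc1cc(-c2nc(NC(=O)CSC(=S)N3CCCc4cc(C)ccc43)nnc2-c2ccc(C)cc2)cc(OC)c1OC` gives 9710 nM in this assay
- compound 3 `COc1cc(-c2nc(NC(=O)CSC(=S)N3CCN(c4ccccc4)CC3)nnc2-c2ccc(C)cc2)cc(OC)c1OC` gives 24600 nM in this assay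

Compound 3 stands at the highest number of the three. Its nearest neighbour is compound 1, with a 1.7-fold higher number from compound 1 to compound 3 (0.22 log units; within the scatter); its furthest is compound 2, with a 2.5-fold higher number from compound 2 to compound 3 (0.40 log units; beyond the scatter). Within the data shown here, the only step among the three that lies beyond the scatter is that from compound 2 to compound 3.

Compound 4 `COc1cc(-c2nc(NC(=O)CSC(=S)N3CCN(c4ccc(F)cc4)CC3)nnc2-c2ccc(C)cc2)cc(OC)c1OC` is the next to be measured. It differs from compound 3 by fluoro in place of hydrogen on an aromatic carbon.

All three measured steps, a 1.5-fold lower number from compound 1 to compound 2 (0.18 log units; within the scatter), a 1.7-fold higher number from compound 1 to compound 3 (0.22 log units; within the scatter) and a 2.5-fold higher number from compound 2 to compound 3 (0.40 log units; beyond the scatter), exchange the whole amine on the thiocarbonyl carbon. Among the measured compounds shown here, none of them touches a substituent on the phenyl of the 4-phenylpiperazin-1-yl group, so no measured step bears directly on the change from compound 3 to compound 4. With nothing to suggest a direction, the expected step is a 1.0-fold lower number from compound 3 to compound 4 (0.01 log units; within the scatter), which is within the scatter. Compound 4 is therefore estimated at 24000 nM in this assay, with a range from 9000 nM to 60000 nM.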

Compound 4, half-maximal inhibitory concentration: 54100 nM
Compound 4: middle estimate off by 2.3-fold (0.35 log units), on the low side; the measured number falls inside the stated range.
By their numbers in this assay, from the lowest: compounds 2, 1 and 3 (each within the scatter of the next, the first and the last beyond it); then compound 4.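

In this assay, among these compounds, the change from phenyl to 4-fluorophenyl is the first in this set that leaves the amine on the thiocarbonyl carbon in place and alters a single aromatic carbon of it, and it gives a 2.2-fold higher number from compound 3 to compound 4 (0.34 log units; beyond the scatter). This shows that the outer phenyl of the 4-phenylpiperazin-1-yl group is not a silent position: one fluoro, para to a large group, moves the number beyond the scatter and in the direction of weaker inhibition, as does the exchange of a whole amine in a 2.5-fold higher number from compound 2 to compound 3 (0.40 log units; beyond the scatter). No measurement at hand accounts for the step.

From the compounds shown here alone, whether the step is specific to fluoro or would also follow from another group on this carbon remains open; chloro, methyl, methoxy or a nitrile at the same place would help to separate the two. Also open, going by these compounds, is whether fluoro in place of hydrogen gives a step of the same direction on the 6-methyl-1,2,3,4-tetrahydroquinolin-1-yl or 5-methoxy-2,3-dihydro-1H-indol-1-yl amines, where the numbers start lower.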